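Adding a side chain to the amino group of compound 2

The compounds below may be only part of what the source reports. "The series", "measured", "known", "first", "only" and "open" are said of these compounds alone.

In a functional assay on K562 cells (Homo sapiens) for cytotoxicity, read by trypan blue exclusion, with a stated time of 96 h (a higher number here means a weaker inhibitor, a lower number a stronger inhibitor), compound 1 `COc1cc(OC)c(/C=C/S(=O)(=O)Nc2ccc(OC)c(F)c2)c(OC)c1` gives 75 nM, while compound 2 `COc1cc(OC)c(/C=C/S(=O)(=O)Nc2ccc(OC)c(N)c2)c(OC)c1` gives 3 nM, the lower of the two numbers and so the stronger result. The two differ in one place, with amino in place of fluoro on an aromatic carbon. That single change produced the step of a 25-fold lower number from compound 1 to compound 2 (1.40 log units; beyond the scatter), which is large and beyond the scatter.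

Compound 3 `COC(=O)CNc1cc(NS(=O)(=O)/C=C/c2c(OC)cc(OC)cc2OC)ccc1OC` keeps the core of compound 2 but alters its amino group: (methoxycarbonyl)methyl in place of hydrogen on a nitrogen on an aromatic ring. Here (methoxycarbonyl)methyl stands in place of hydrogen on a nitrogen on an aromatic ring, turning amino into ((methoxycarbonyl)methyl)amino. Among the measured compounds shown here, no measured compound carries anything on this nitrogen, so the data give no direct guide to the effect of this change. For the measured compounds named here, the one measured step, a 25-fold lower number from compound 1 to compound 2 (1.40 log units; beyond the scatter), shows only that a change in this place can move the number substantially. A moderate rise in the number is therefore expected in this assay, smaller than that step, and the expected step is a 3.3-fold higher number from compound 2 to compound 3 (0.52 log units; beyond the scatter). For compound 3, the estimated value is 10 nM, with an expected range of 3 nM to 40 nM.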

Compound 3, half-maximal inhibitory concentration: 350 nM
The estimate for compound 3 lay 35-fold (1.54 log units) below the measured number, and the stated range ends below it.
By their numbers in this assay, from the lowest: compound 2; then compound 1; then compound 3.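

In this assay, the amino nitrogen of compound 2 turns out to tolerate this side chain poorly: adding (methoxycarbonyl)methyl gives a 120-fold higher number from compound 2 to compound 3 (2.07 log units; beyond the scatter), so the amino group's strong result depends on more than having a nitrogen at this place. The added chain does more than cancel the gain that amino gave over fluoro, since the comparison with the fluoro compound shows a 4.7-fold higher number from compound 1 to compound 3 (0.67 log units; beyond the scatter), leaving the substituted amine behind fluoro in this assay. This is a single side chain, so it shows what this one group does to the number and sets no rule for other groups on this nitrogen, and no measurement at hand explains the size of the loss.

The compounds shown leave open whether the loss belongs to the methoxycarbonyl end of the chain or follows from placing almost any carbon group on the nitrogen. A plain methyl group on the nitrogen, a carboxylic acid at the end of the same chain, or a longer chain ending in an amine would help to separate these possibilities.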